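Taking One Hydroxy Group Away from Compound 2

The source may report more compounds than this note shows. Statements on the series, on what has been measured and on what is new or still open speak of the compounds shown alone.

Of the compounds shown here, two built on a shared core have been tested so far in a functional assay on Caco-2 cells (Homo sapiens) for antiproliferative activity, read by MTT assay, with a stated time of 48 h; a higher number here means a weaker inhibitor, a lower number a stronger inhibitor. Compound 1 `C=C(C(=O)O)[C@@H]1CC[C@@]2(C)CCC(=O)C(C)=C2C1` gives 39000 nM. Among the compounds with values here, compound 2 `C=C(C(=O)O)[C@@H]1CC[C@]2(C)C(=C(C)C(=O)[C@@H](O)[C@H]2O)C1` gives 66000 nM, a value within the usual scatter of the one for compound 1, so these numbers cannot separate the pair. Compound 3 `C=C(C(=O)O)[C@@H]1CC[C@@]2(C)C[C@H](O)C(=O)C(C)=C2C1` has not yet been measured. It differs from compound 2 by hydrogen in place of hydroxy on a saturated ring carbon, with hydrogen in place of hydroxy on a saturated ring carbon. Within the data shown here, no measured pair shows this single change alone. Still, compound 1 at 39000 nM lacks the hydroxy groups of compound 2 at 66000 nM, and the two values stay close. The expected change is a 1.3-fold lower number from compound 2 to compound 3 (0.12 log units; within the scatter), an estimate that remains within the scatter. For compound 3 the estimated value is 50000 nM, with an expected range of 25000 nM to 100000 nM.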

Compound 3, half-maximal inhibitory concentration: 60000 nM
Estimate against measurement, compound 3: 1.2-fold (0.08 log units) below; low and high end bracket the measured number.
By their numbers in this assay, from the lowest: compounds 1, 3 and 2 (each within the scatter of the next).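

In this assay this change can now be read on its own: hydrogen in place of hydroxy on a saturated ring carbon gives a 1.1-fold lower number from compound 2 to compound 3 (0.04 log units; within the scatter) and so cannot be told apart from no change at all. The other hydroxy group behaves the same way, since hydroxy in place of hydrogen on a different saturated ring carbon gives a 1.5-fold higher number from compound 1 to compound 3 (0.19 log units; within the scatter) and also leaves the two numbers unseparated. Taken singly, neither hydroxy group shows a readable influence on the number in these compounds.

The compounds shown carry only hydrogen or hydroxy on this carbon, so it stays open whether an amine or a longer chain there would move the number beyond the scatter. Nothing measured here offers an explanation for how close these values lie.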